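A few compounds are considered here, and "the series" means these few. Any claim that something is new, unique, unknown or untested is made for them only; others in the source may bear on it.

Compound 1, `COc1cc(-c2cc(-c3cc(C(C)C)c(O)cc3C)[nH]c(=O)c2C#N)cc(OC)c1OC`: 35%
Compound 2, `COc1ccc(-c2cc(-c3cc(C(C)C)c(O)cc3C)[nH]c(=O)c2C#N)cc1`: 24%

In a functional assay for inhibition, tested at 20 ug/mL (a lower number here means a weaker effect, a higher number a stronger effect of the compound at the concentration tested), compound 1 gives the higher of the two numbers, and its gap to compound 2 lies beyond the usual scatter of such measurements. Compound 3, `COc1ccc(-c2cc(-c3cc(C(C)C)c(O)cc3C)[nH]c(=O)c2C#N)cc1OC`, has not yet been measured. It differs from compound 1 in one place: hydrogen in place of methoxy on an aromatic carbon. Going by the values given here, no measured pair shows exactly this change, so its size is uncertain. Compound 2, carrying one methoxy group only, gives 24%. For compound 3 a modest drop is therefore expected, the estimated step being a number 6 percentage points lower from compound 1 to compound 3 (within the scatter). Compound 3 is estimated at 29%, within a range of 16% to 42%.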

Compound 3, a percentage reported as inhibition, at one concentration (the size of the read-out at that concentration, not a potency): 25%
Compound 3: middle estimate off by 4 percentage points, on the high side, within the range that was stated.
By their numbers in this assay, from the lowest: compounds 2, 3 and 1 (each within the scatter of the next, the first and the last beyond it).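

In this assay, hydrogen in place of the methoxy group gives a number 10 percentage points lower from compound 1 to compound 3 (within the scatter) and so, taken alone, losing this methoxy cannot be told apart from repeat scatter. The other one-place step, methoxy in place of hydrogen, gives a number 1 percentage points higher from compound 2 to compound 3 (within the scatter) and is just as unresolved. Nothing available here offers a reason for either step.

From the compounds shown here alone, whether an amine, a hydroxyl group or a longer ether chain at this aromatic carbon would give a step beyond the scatter stays open. So does how these compounds would behave at other concentrations, since a single-concentration read-out is not a potency.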